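Caffeic ester amides: cytotoxicity notes ahead of compound 3

This account rests on a few compounds, and the source may have more. Where it says the series, first, only, none or still open, it means among the compounds named here.

Measured so far:
compound 1 `COc1ccc(/C=C/C(=O)OCC(=O)Nc2ccccc2)cc1OC` — > 200000 nM (a limit of the assay)
compound 2 `COCOc1cc(/C=C/C(=O)OCC(=O)Nc2ccc(Cl)cc2)ccc1OCc1ccccc1` — > 200000 nM (a limit of the assay)

In a functional assay on LS174T cells (Homo sapiens) for cytotoxicity, read by MTT assay, with a stated time of 72 h (on this read-out lower numbers stand for stronger inhibition and higher numbers for weaker inhibition), compound 1 gives > 200000 nM, which is a limit of the assay and not a number. In this assay compound 2 likewise gives only > 200000 nM, again a limit. For the measured compounds named here, both values sit at the same limit (the limit of > 200000 nM in this assay, at which 2 of the 2 values shown sit), so no step between them can be measured, and nothing in these two results shows one compound to be stronger than the other.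

Compound 3 `COCOc1cc(/C=C/C(=O)OCC(=O)NN2CCOCC2)ccc1OCc1ccccc1` differs from compound 2 in one place: morpholin-4-yl in place of 4-chlorophenyl on an amide-type nitrogen. Going by the values given here, no step between measured compounds is available, so what a change on the amide-type nitrogen does to cytotoxicity is not known from these data.

In this assay the step from compound 2 to compound 3 is expected to be a number no higher from compound 2 to compound 3 (the limit leaves the size open), that is, none beyond the scatter. Compound 3 is therefore estimated at 200000 nM in this assay, with a further limit rather than a number being the likelier outcome.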

Compound 3, half-maximal inhibitory concentration: > 200000 nM
Compound 3 gave a limit, no number; the forecaster's own chance of this, stated with the estimate: 70%; the middle value sits exactly at the limit.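

In this assay compound 3 gives > 200000 nM as a limit of the assay and not a number. For the compounds shown here, no step from compound 2 to compound 3 can be read, because both stand at the same limit: the limit of > 200000 nM in this assay, at which 3 of the 3 values shown sit.

The compounds shown leave open whether any change on the amide-type nitrogen alters cytotoxicity at all, as none of them gives a number.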